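Swapping a Sulfur Chain for a Cyclopentyl Ring

This account rests on a few compounds, and the source may have more. Where it says the series, first, only, none or still open, it means among the compounds named here.

Compound 1 `CSCC/C=N/Nc1nc(N)c2ncn([C@@H]3O[C@H](CO)[C@@H](O)[C@H]3O)c2n1` gives > 10000 nM in an assay on CHO-K1 cells for displacement of a labelled ligand from adenosine receptor A1 (Homo sapiens), read by scintillation counting, with a stated time of 60 min; on this read-out lower numbers stand for stronger inhibition and higher numbers for weaker inhibition; this is a limit of the assay, not a number.
Compound 2 `Nc1nc(N/N=C/c2ccc(OCc3ccccc3)c(OCc3ccccc3)c2)nc2c1ncn2[C@@H]1O[C@H](CO)[C@@H](O)[C@H]1O` gives > 10000 nM in this assay; this too is a limit.
Compound 3 `Nc1nc(N/N=C/c2ccc(N(c3ccccc3)c3ccccc3)cc2)nc2c1ncn2[C@@H]1O[C@H](CO)[C@@H](O)[C@H]1O` gives > 10000 nM in this assay; again a limit.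

All three measured compounds share one core and differ only in the group hanging from the carbon with a double bond to nitrogen. Among the compounds with values here, none of them gives a number: each sits at the limit, as the limit of > 10000 nM in this assay, at which 3 of the 3 values shown sit, sets out, so no step between measured compounds can be drawn. Compound 1 therefore stands nowhere in particular on the scale; only its limit is known.

Compound 4 `Nc1nc(N/N=C/C2CCCC2)nc2c1ncn2[C@@H]1O[C@H](CO)[C@@H](O)[C@H]1O` is the next variation and is not yet measured. It differs from compound 1 in one place: cyclopentyl in place of 2-(methylsulfanyl)ethyl on a carbon with a double bond to nitrogen. A newcomer should note that the change is small in size and keeps the same attachment point, while the other two measured compounds carry much larger aromatic groups at that position and still give only a limit.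

With nothing measured above the limit, the step from compound 1 to compound 4 is expected to be a step that the limit leaves unreadable from compound 1 to compound 4, that is, no change that could be told from the scatter. Compound 4 is thus estimated at 15000 nM in this assay, with a range from 4000 nM to 60000 nM.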

Compound 4, inhibition constant: 5.6 nM
Beside the measured number, compound 4's estimate is 2700-fold (3.43 log units) above it, and the stated range ends above it.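

In this assay, cyclopentyl in place of 2-(methylsulfanyl)ethyl on a carbon with a double bond to nitrogen gives an at least 1700-fold lower number from compound 1 to compound 4 (3.25 log units; beyond the scatter), so the group at this place can decide whether the compound registers as a measured number at all. The swap is modest on paper, with 4 heavy atoms leaving and 5 entering, yet it carries the compound from a limit of the assay to a real value, which shows that this read-out responds strongly to small changes in this group. Compound 4 is the only compound shown with a real number, and every other value is a limit of the assay: the limit of > 10000 nM in this assay, at which 3 of the 4 values shown sit.

The change does two things at once, removing the sulfur and closing a ring, and these compounds cannot separate the two; an open pentyl chain at the same place would test the need for a ring, while a cyclobutyl or cyclohexyl ring would test how much the ring size matters. From the compounds shown here alone, whether a plain phenyl ring, or a cyclopentyl ring bearing an amine or a hydroxyl group, would be accepted here also remains open.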